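Cyano in place of methoxy on the shared core

This account rests on a few compounds, and the source may have more. Where it says the series, first, only, none or still open, it means among the compounds named here.

Measured so far in a functional assay on cells for agonist activity at Free fatty acid receptor 1 (Mus musculus), read by FLIPR and calcium flux, with a stated time of 5 min; on this read-out higher numbers stand for an effect only at larger amounts of compound and lower numbers for an effect already at smaller amounts:
compound 1 `Cc1nn(-c2ccccn2)c2cc(-c3ccc(CCC(=O)O)cc3)ccc12` gives 1400 nM
compound 2 `Cc1nn(-c2ccccn2)c2cc(-c3ccc(CCC(=O)O)cc3Cl)ccc12` gives 1200 nM
compound 3 `COc1nn(-c2ccccn2)c2cc(-c3ccc(CCC(=O)O)cc3)ccc12` gives 2600 nM

Compound 3 carries the highest number of the three. Its nearest neighbour is compound 1, whose number is lower, but the step of a 1.9-fold higher number from compound 1 to compound 3 (0.27 log units; within the scatter) is within the scatter of repeated measurements. Compound 2 gives 1200 nM, and the gap between compound 3 and compound 2 is beyond the scatter, so compound 3 is at the weaker end of this small set, though not separated from every other compound.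

The next compound, compound 4 `N#Cc1nn(-c2ccccn2)c2cc(-c3ccc(CCC(=O)O)cc3)ccc12`, differs from compound 3 in one place: cyano in place of methoxy on an aromatic carbon.

Among the measured compounds shown here, no measured step swaps these two groups. The step that touches the same position is a 1.9-fold higher number from compound 1 to compound 3 (0.27 log units; within the scatter), which exchanged methyl for methoxy and stayed within the scatter. The other step, a 1.2-fold lower number from compound 1 to compound 2 (0.07 log units; within the scatter), concerns a chloro on a different ring and was also within the scatter. Both steps were small, so a small step is expected here too, with no clear direction. The expected step is a 1.3-fold lower number from compound 3 to compound 4 (0.11 log units; within the scatter). Compound 4 is therefore estimated to give 2000 nM, with a range from 700 nM to 6000 nM.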

Compound 4, half-maximal effective concentration: 2000 nM
Beside the measured number, compound 4's estimate shows no gap at the digits printed; low and high end bracket the measured number.
By their numbers in this assay, from the lowest: compounds 2, 1, 4 and 3 (each within the scatter of the next, the first and the last beyond it).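

Swapping in cyano adds a third group to this aromatic carbon of the five-membered ring, and in this assay it cannot be told apart from either group measured there before (a 1.3-fold lower number from compound 3 to compound 4 (0.11 log units; within the scatter), and a 1.4-fold higher number from compound 1 to compound 4 (0.15 log units; within the scatter)). The earlier compounds shown here showed this only for methyl and methoxy, whereas the nitrile brings a triple bond and puts nitrogen where methoxy has oxygen, and neither step leaves the scatter of repeated measurements. Among these three groups, then, the choice at this position does not separate the compounds on this read-out, and nothing measured alongside the numbers speaks to why.

Still open, going by these compounds, is whether a group of a different kind on this carbon, such as an amine, a carboxylic acid or a longer chain, would give a step beyond the scatter, in either direction. Also open is whether cyano here would behave the same way with the chloro of compound 2 on the other ring, since the two changes appear together in none of the compounds shown.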